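Swapping the Amide Substituent on a Shared Inhibitor Core

The source may hold more compounds than are shown below. What is called first, only, known or untested is meant among the compounds shown, and "the series" means these compounds.

Compound 3 `CN1CCC(NC(=O)c2ccncc2Nc2cc(-c3ccc4ccn(C)c4c3)c3nccnc3c2)CC1=O` gives 41 nM in an assay for inhibition of 6-phosphofructo-2-kinase/fructose-2,6-bisphosphatase 3 (Homo sapiens), read by ADP-Glo, with a stated time of 2 h (on this read-out lower numbers stand for stronger inhibition and higher numbers for weaker inhibition), the second highest of three numbers. Compound 1 `Cn1ccc2ccc(-c3cc(Nc4cnccc4C(=O)NCc4cncnc4)cc4nccnc34)cc21` gives 106 nM and compound 2 `Cn1cc(NC(=O)c2ccncc2Nc2cc(-c3ccc4ccn(C)c4c3)c3nccnc3c2)cn1` gives 33 nM. The steps of a 3.2-fold lower number from compound 1 to compound 2 (0.51 log units; beyond the scatter) and a 2.6-fold lower number from compound 1 to compound 3 (0.41 log units; beyond the scatter) were modest, while a 1.2-fold higher number from compound 2 to compound 3 (0.09 log units; within the scatter) lay within the scatter, so two quite different groups on the amide-type nitrogen gave much the same result. Compound 4 `CC(=O)N1CC(NC(=O)c2ccncc2Nc2cc(-c3ccc4ccn(C)c4c3)c3nccnc3c2)C1` differs from compound 3 by 1-acetylazetidin-3-yl in place of 1-methyl-2-oxopiperidin-4-yl on an amide-type nitrogen, again a change at that nitrogen. Because a 1.2-fold higher number from compound 2 to compound 3 (0.09 log units; within the scatter) stayed within the scatter, the expected step is small: a 1.1-fold higher number from compound 3 to compound 4 (0.04 log units; within the scatter). Compound 4 is therefore estimated at 45 nM, with a range from 20 nM to 110 nM.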

Compound 4, half-maximal inhibitory concentration: 73 nM
For compound 4 the middle estimate is 1.6-fold (0.21 log units) below the measured one; low and high end bracket the measured number.
By their numbers in this assay, from the lowest: compounds 2, 3, 4 and 1 (each within the scatter of the next, the first and the last beyond it).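

In this assay, the four-membered ring of 1-acetylazetidin-3-yl in place of the six-membered ring of 1-methyl-2-oxopiperidin-4-yl on the amide-type nitrogen leaves the result within the scatter (a 1.8-fold higher number from compound 3 to compound 4 (0.25 log units; within the scatter)). Compound 4 also cannot be told apart from the (pyrimidin-5-yl)methyl compound (a 1.5-fold lower number from compound 1 to compound 4 (0.16 log units; within the scatter)), yet it separates modestly from the 1-methyl-1H-pyrazol-4-yl compound (a 2.2-fold higher number from compound 2 to compound 4 (0.34 log units; beyond the scatter)). No supporting evidence accompanies these results to explain them.

On these data alone, whether a basic amine, a carboxylic acid or a longer alkyl chain on this nitrogen would fit the same range stays open.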